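The compounds below may be only part of what the source reports. "The series", "measured", "known", "first", "only" and "open" are said of these compounds alone.

In a functional assay on HepG2 cells (Homo sapiens) for antiproliferative activity, read by MTT assay, with a stated time of 72 h (on this read-out higher numbers stand for weaker inhibition and lower numbers for stronger inhibition), compound 2 `FC(F)(F)c1ccc(COc2cccc(Nc3ncnc4cc5c(cc34)OCCOCCOCCOCCO5)c2)cc1` gives 5700 nM, the only number among the three results shown. Compound 1 `O=[N+]([O-])c1ccc(COc2ccc(Nc3ncnc4cc5c(cc34)OCCOCCO5)cc2)cc1` reaches only a limit of the assay, > 100000 nM. Compound 3 `O=[N+]([O-])c1ccc(COc2cccc(Nc3ncnc4cc5c(cc34)OCCOCCOCCO5)c2)cc1` likewise stops at a limit, > 100000 nM. Compound 4 `O=[N+]([O-])c1ccc(COc2cccc(Nc3ncnc4cc5c(cc34)OCCOCCOCCOCCO5)c2)cc1` keeps the shared core of compound 2 and differs from it in one place: nitro in place of trifluoromethyl on an aromatic carbon. Going by the values given here, no step between two measured compounds is available, so the size of this change can only be expected. Two of the three results sit at the limit of > 100000 nM in this assay, at which 2 of the 3 values shown sit, and both carry the nitro group that enters here, so compound 4 is expected to weaken beyond the scatter, with an expected step of an 11-fold higher number from compound 2 to compound 4 (1.02 log units; beyond the scatter). Compound 4 is estimated at 60000 nM, between 15000 nM and 200000 nM, with a fair chance that only a limit is reported.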

Compound 4, half-maximal inhibitory concentration: 9820 nM
For compound 4 the middle estimate is 6.1-fold (0.79 log units) above the measured one, and the stated range ends above it.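

In this assay the change of trifluoromethyl to nitro, on an aromatic carbon para to a large group, gives a 1.7-fold higher number from compound 2 to compound 4 (0.24 log units; within the scatter) on this shared core. At this position, and on this core, the two groups therefore cannot be told apart. Compound 4 carries nitro and still returns a number, so nitro alone does not place a compound at the limit: the limit of > 100000 nM in this assay, at which 2 of the 4 values shown sit.

Open, going by these compounds, is how other groups at this position, such as an amine or a carboxylic acid, would read. Also open, on these data alone, is whether trifluoromethyl and nitro would stay within the scatter of each other on the cores of compound 1 and compound 3.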